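The source may hold more compounds than are shown below. What is called first, only, known or untested is meant among the compounds shown, and "the series" means these compounds.

Measured so far, in a functional assay on MCF7 cells (Homo sapiens) for inhibition, read by MTT assay, with a stated time of 72 h; a lower number here means a stronger inhibitor of growth, a higher number a weaker inhibitor of growth:
- compound 1 `CC(C)(C)c1ccc(CNCCCNS(=O)(=O)c2cc(C(F)(F)F)cc(C(F)(F)F)c2)cc1` gives 2100 nM
- compound 2 `O=S(=O)(NCCCNCc1ccc(Cl)c(C(F)(F)F)c1)c1cc(C(F)(F)F)cc(C(F)(F)F)c1` gives 3500 nM
- compound 3 `O=S(=O)(NCCCNCc1ccc(-c2ccccc2)cc1)c1cc(C(F)(F)F)cc(C(F)(F)F)c1` gives 1700 nM

All three share the same core: a sulfonamide joined through a three-carbon chain to an amine, which in turn carries a benzyl group whose aromatic ring differs from compound to compound. Compound 3 stands at the lowest of the three numbers in this assay, but its gap to compound 1 is small, a 1.2-fold lower number from compound 1 to compound 3 (0.09 log units; within the scatter), while compound 2 sits beyond the scatter from it.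

Compound 4 `COc1ccc(CNCCCNS(=O)(=O)c2cc(C(F)(F)F)cc(C(F)(F)F)c2)cc1` keeps everything except the group on that benzyl ring: methoxy in place of phenyl on an aromatic carbon.

Two measured steps speak to changes at this same ring. From compound 1 to compound 3 the result was a 1.2-fold lower number from compound 1 to compound 3 (0.09 log units; within the scatter), and from compound 1 to compound 2, where the whole ring substitution pattern changed, it was a 1.7-fold higher number from compound 1 to compound 2 (0.22 log units; within the scatter). Neither swap at this ring moved the number beyond the scatter, so a step from compound 3 to compound 4 in this assay is expected to be small as well, perhaps a slightly higher number but not beyond the scatter, a 1.5-fold higher number from compound 3 to compound 4 (0.17 log units; within the scatter).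

Compound 4 is therefore estimated at 2500 nM in this assay, with an expected range from 1200 nM to 5500 nM.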

Compound 4, concentration for 50% growth inhibition: 2500 nM
Compound 4: middle estimate and measured number agree at the digits printed; the measured number falls inside the stated range.
By their numbers in this assay, from the lowest: compounds 3, 1, 4 and 2 (each within the scatter of the next, the first and the last beyond it).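

In this assay, the phenyl group gives way to the much smaller methoxy, which has no ring and brings in an oxygen and a hydrogen-bond acceptor, yet the result is only a small step (a 1.5-fold higher number from compound 3 to compound 4 (0.17 log units; within the scatter)). The same methoxy group in place of tert-butyl on the aromatic carbon (a 1.2-fold higher number from compound 1 to compound 4 (0.08 log units; within the scatter)) and 4-methoxyphenyl in place of 4-chloro-3-(trifluoromethyl)phenyl on the chain carbon (a 1.4-fold lower number from compound 2 to compound 4 (0.15 log units; within the scatter)) also stay within the scatter, so compound 4 cannot be separated from any of the other three, and even a large change in the size of this group need not move the number much. Nothing measured alongside these numbers bears on what lies behind so small a response.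

From the compounds shown here alone, whether this position answers to a group of a different kind, such as a carboxylic acid or a primary amine on the same aromatic carbon, remains open. So does whether the number would respond more clearly to a change elsewhere in the shared core, such as a longer chain between the sulfonamide and the amine.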